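Swapping the Benzylic Group on an Isoindoledione Sulfonamide

The compounds below may be only part of what the source reports. "The series", "measured", "known", "first", "only" and "open" are said of these compounds alone.

Two close relatives have been measured so far. Compound 1 `Cc1ccc(S(=O)(=O)Nc2ccc3c(c2)C(=O)N(Cc2ccc(Cl)cc2)C3=O)cc1` gives 155000 nM in an assay on isolated protein for inhibition of lactase/phlorizin hydrolase (Rattus norvegicus), read by colorimetric assay; a higher number here means a weaker inhibitor, a lower number a stronger inhibitor. Compound 2 `Cc1ccc(S(=O)(=O)Nc2ccc3c(c2)C(=O)N(CCNc2ccccc2)C3=O)cc1` gives 177000 nM in the same assay. The step between them, a 1.1-fold higher number from compound 1 to compound 2 (0.06 log units; within the scatter), shows that swapping one group for another on the saturated chain carbon bound to the amide-type nitrogen in the ring barely moved the number. Compound 2 thus has the higher of the two numbers, but the gap to compound 1 lies within the scatter, so the two cannot be told apart.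

Compound 3 `Cc1ccc(S(=O)(=O)Nc2ccc3c(c2)C(=O)N(Cc2ccc(Cl)c(Cl)c2)C3=O)cc1` has not yet been measured. Compared with compound 2, the change is 3,4-dichlorophenyl in place of anilinomethyl on a saturated chain carbon bound to an amide-type nitrogen in a ring. For the measured compounds named here, the only step that bears on this is the one from compound 1 to compound 2, which was within the scatter; it covers part of the same ground in reverse, and nothing measured here speaks to the second chlorine. The expectation is therefore a step of a 1.2-fold lower number from compound 2 to compound 3 (0.07 log units; within the scatter), not beyond the scatter. For compound 3 the estimate in this assay is 150000 nM, with a range from 70000 nM to 330000 nM.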

Compound 3, half-maximal inhibitory concentration: 101000 nM
Compound 3: the middle estimate sits 1.5-fold (0.17 log units) above what was measured, and the stated range covers the measured number.
By their numbers in this assay, from the lowest: compounds 3, 1 and 2 (each within the scatter of the next).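

Replacing anilinomethyl with 3,4-dichlorophenyl on the saturated chain carbon bound to the amide-type nitrogen in the ring gives, in this assay, a 1.8-fold lower number from compound 2 to compound 3 (0.24 log units; within the scatter). This shows that the number stays within the scatter even when the hydrogen-bond donor and acceptor counted in anilinomethyl are gone, since the entering group has neither. The other new step adds a chloro in place of hydrogen on an aromatic carbon and gives a 1.5-fold lower number from compound 1 to compound 3 (0.19 log units; within the scatter), so this single added atom also leaves the compounds indistinguishable; no supporting measurement speaks to why the numbers stay so close.

From the compounds shown here alone, all three groups at this position carry a six-membered aromatic ring of carbon only, so it remains open whether a simple amine, a carboxylic acid or a longer chain with no aromatic ring would give a step beyond the scatter. Going by these compounds, on the ring itself, it also remains open whether a methoxy group or a fluorine in place of the chlorine would read any differently from compound 1 or compound 3.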